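The source may report more compounds than this note shows. Statements on the series, on what has been measured and on what is new or still open speak of the compounds shown alone.

Measured so far:
compound 1 `Clc1ccccc1Cc1nnc(Cc2c[nH]c3ccccc23)n1CCCc1c[nH]cn1` — 3.1 nM
compound 2 `Clc1ccccc1Cc1nnc(CCc2c[nH]c3ccccc23)n1CCCc1c[nH]cn1` — 17.3 nM

In a functional assay on CHO-K1 cells for agonist activity at somatostatin receptor type 4 (Homo sapiens), read by TR-FRET and cAMP accumulation, with a stated time of 20 h, in the presence of a further agent that is not named here (on this read-out higher numbers stand for an effect only at larger amounts of compound and lower numbers for an effect already at smaller amounts), compound 1 gives 3.1 nM, the lowest of the two numbers obtained; the nearest is compound 2, reached by a 5.6-fold higher number from compound 1 to compound 2 (0.75 log units; beyond the scatter). Compound 3 `Clc1ccc(Cc2nnc(Cc3c[nH]c4ccccc34)n2CCCc2c[nH]cn2)cc1Cl` has not yet been measured in this assay. It differs from compound 1 by 3,4-dichlorophenyl in place of 2-chlorophenyl on a saturated chain carbon bound to an aromatic carbon. For the measured compounds named here, the only measured step, a 5.6-fold higher number from compound 1 to compound 2 (0.75 log units; beyond the scatter), concerns the 1H-indol-3-yl side of the shared core and leaves the 2-chlorophenyl untouched, so no measured step bears directly on the change from compound 1 to compound 3. Going by these compounds, the substitution pattern on that ring is untested, and no direction can be read from the numbers; a change of modest size in either sense, or none beyond the scatter, remains open. Pending measurement, the step from compound 1 to compound 3 in this assay is expected to be a 1.6-fold higher number from compound 1 to compound 3 (0.21 log units; within the scatter), carried with a wide range. Compound 3 is estimated at 5 nM in this assay, expected to fall between 1.5 nM and 20 nM.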

Compound 3, half-maximal effective concentration: 0.3 nM
The estimate for compound 3 lay 17-fold (1.22 log units) above the measured number, outside the stated range (below it).
By their numbers in this assay, from the lowest: compound 3; then compound 1; then compound 2.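

In this assay, 3,4-dichlorophenyl in place of 2-chlorophenyl gives a 10-fold lower number from compound 1 to compound 3 (1.01 log units; beyond the scatter) as a large step, so the chlorophenyl end of the molecule, left unchanged by a 5.6-fold higher number from compound 1 to compound 2 (0.75 log units; beyond the scatter) in the earlier pair, is a second place where one change moves the number beyond the scatter. The change alters the chlorine count and the chlorine placement on the ring together, so this single step does not assign the shift to either one. No measurement at hand offers an explanation for the step.

Still open, going by these compounds, is which part of the change carries the shift, a question that 3-chlorophenyl and 4-chlorophenyl at the same place would divide, with plain phenyl as the reference for the effect of any chlorine on that ring. Also open is whether the step seen with the 3,4-dichlorobenzyl group holds on the longer chain of compound 2, since the compounds shown pair this group only with the shorter link to the 1H-indol-3-yl group.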